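Methoxycarbonyl to propoxycarbonyl on two related cores

The source may hold more compounds than are shown below. What is called first, only, known or untested is meant among the compounds shown, and "the series" means these compounds.

Measured so far:
- compound 1, `COC(=O)C1=C(C)NC(=S)NC1c1cccs1`, gives 1% in an assay on membranes from CHO cells for displacement of a labelled ligand from adenosine receptor A1 (Homo sapiens), read by scintillation counting, with a stated time of 60 min, tested at 1 uM; on this read-out higher numbers stand for more inhibition at the one concentration tested (going by the name of the read-out) and lower numbers for less inhibition
- compound 2, `CCCOC(=O)C1=C(C)NC(=S)NC1c1cccs1`, gives 7% in this assay
- compound 3, `COC(=O)C1=C(C)N(C)C(=O)NC1c1ccoc1`, gives 15% in this assay

Compounds 1 and 2 share one core and differ only by ethyl in place of hydrogen on a saturated chain carbon bound to an oxygen next to a carbonyl group. In this assay that change made a number 6 percentage points higher from compound 1 to compound 2 (within the scatter), so the two numbers cannot be told apart. Compound 3 carries a different core; the difference between the two cores is not broken down here. Compound 3 stands beyond the scatter above compound 1 but within the scatter of compound 2, so no ranking among the three is secure.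

Compound 4, `CCCOC(=O)C1=C(C)N(C)C(=O)NC1c1ccoc1`, is not yet measured. It differs from compound 3 by ethyl in place of hydrogen on a saturated chain carbon bound to an oxygen next to a carbonyl group, the same change as between compound 1 and compound 2, at the same place. Among the compounds with values here, the only guide is that earlier pair, where the step was a number 6 percentage points higher from compound 1 to compound 2 (within the scatter), a size that lies inside the ordinary scatter. With the new core the effect could be somewhat different, so the range around the estimate is kept wide.

Compound 4 is therefore expected to give about 20% in this assay, most likely between 8% and 33%. The step this estimate means, a number 5 percentage points higher from compound 3 to compound 4 (within the scatter), is expected to be small because a number 6 percentage points higher from compound 1 to compound 2 (within the scatter) was small.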

Compound 4, a percentage reported as inhibition, at one concentration (the size of the read-out at that concentration, not a potency): 1%
Estimate against measurement, compound 4: 19 percentage points above; measured number below the stated range.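

On the core of compound 3, replacing methoxycarbonyl with propoxycarbonyl gave a number 14 percentage points lower from compound 3 to compound 4 (beyond the scatter) in this assay. The change therefore does not carry a single effect from one core to the other in this series, and the step on the core of compound 1 is a poor guide to the step on the core of compound 3: the same change on two cores in this assay, a number 6 percentage points higher (within the scatter) from compound 1 to compound 2 and a number 14 percentage points lower (beyond the scatter) from compound 3 to compound 4, 20 percentage points apart, beyond the scatter of two such steps This rests on one pair per core, each read at a single concentration, so it shows neither the reason for the difference nor how the change would behave on any further core, and it gives no information on potency.

The compounds shown leave open how the trend continues along the ester, since they include neither an ethoxycarbonyl nor a butoxycarbonyl group, and how a carboxylic acid or a primary amide in place of the methoxycarbonyl group would read on either core. The two cores also differ in more than one place, and no pair shown changes these places one at a time, so which of those differences goes with the different outcome of the ester change remains unresolved.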